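The source may hold more compounds than are shown below. What is called first, only, known or untested is meant among the compounds shown, and "the series" means these compounds.

Measured in a functional assay on SK-BR-3 cells (Homo sapiens) for antiproliferative activity; on this read-out lower numbers stand for stronger inhibition and higher numbers for weaker inhibition:
- compound 1 `CC(C)=CCc1cc(C(=O)Nc2cc3ccc(OCC4CCCN(C)C4)c(C)c3oc2=O)ccc1O`: 1300 nM
- compound 2 `CCNCCCOc1ccc2cc(NC(=O)c3ccc(O)c(CC=C(C)C)c3)c(=O)oc2c1C`: 720 nM
- compound 3 `COC(=O)CNCCCOc1ccc2cc(NC(=O)c3ccc(O)c(CC=C(C)C)c3)c(=O)oc2c1C`: 1060 nM

All three compounds share one core and differ in the chain on its oxygen. Compound 3, at 1060 nM, sits within the scatter of both others: the step is a 1.2-fold lower number from compound 1 to compound 3 (0.09 log units; within the scatter), and a 1.5-fold higher number from compound 2 to compound 3 (0.17 log units; within the scatter). The third measured step, a 1.8-fold lower number from compound 1 to compound 2 (0.26 log units; within the scatter), is also small.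

Compound 4 `CC(C)=CCc1cc(C(=O)Nc2cc3ccc(OCCCNCC(=O)O)c(C)c3oc2=O)ccc1O` has hydrogen in place of methyl on an oxygen next to a carbonyl group, so methoxycarbonyl becomes carboxy (hydrogen in place of methyl on an oxygen next to a carbonyl group). Within the data shown here, no measured compound carries a carboxy group, so no step tests this change directly. The closest evidence is the swap that introduced methoxycarbonyl, a 1.5-fold higher number from compound 2 to compound 3 (0.17 log units; within the scatter), which moved the number little. A large step is therefore not expected, though a new group leaves real uncertainty, and a slight lean towards a higher number is only a judgement. The expected change is a 1.7-fold higher number from compound 3 to compound 4 (0.23 log units; within the scatter). For compound 4 the estimated value is 1800 nM, within an expected range of 600 nM to 7000 nM.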

Compound 4, half-maximal inhibitory concentration: 7570 nM
Compound 4: the middle estimate sits 4.2-fold (0.62 log units) below what was measured; the whole stated range lies below it.
By their numbers in this assay, from the lowest: compounds 2, 3 and 1 (each within the scatter of the next); then compound 4.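

In this assay, among these compounds, the chain on the oxygen of the shared core had so far produced only small steps, but one small edit, hydrogen in place of methyl on an oxygen next to a carbonyl group, now gives a clear loss ((a 7.1-fold higher number from compound 3 to compound 4 (0.85 log units; beyond the scatter))). Compound 4 also stands apart from the other two chains (an 11-fold higher number from compound 2 to compound 4 (1.02 log units; beyond the scatter); a 5.8-fold higher number from compound 1 to compound 4 (0.77 log units; beyond the scatter)), so at this position carboxy is separated from methoxycarbonyl, and from the ethylamino and methylpiperidine chains, by far more than those three are separated from one another. No measurement available here explains the gap.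

Still open, from the compounds shown here alone, is whether an ethyl ester or a primary amide in place of the carboxy group would stay close to compound 3 or fall towards compound 4. A longer chain between the amine and the carboxy group is also untested by these compounds.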